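From dipentylamino to (tert-butyl)amino

The compounds below may be only part of what the source reports. "The series", "measured", "known", "first", "only" and "open" are said of these compounds alone.

In a functional assay (aorta) with Rattus norvegicus as the target (a higher number here means a weaker inhibitor, a lower number a stronger inhibitor), compound 1 (`CC(C)(C)NCCCOc1ccc(S(=O)(=O)c2c(C3CC3)cn3ccccc23)cc1`) gives 66.5 nM and compound 2 (`CCCCCN(CCCCC)CCCOc1ccc(S(=O)(=O)c2c(CC)cn3ccccc23)cc1`) gives 62.4 nM, so these two values lie within the scatter of each other. Compound 3 (`CCc1cn2ccccc2c1S(=O)(=O)c1ccc(OCCCNC(C)(C)C)cc1`) has not yet been measured, and its difference from compound 2 is (tert-butyl)amino in place of dipentylamino on a saturated chain carbon, three bonds along the chain from an oxygen on an aromatic ring. Compound 1 also carries (tert-butyl)amino, on a core of its own, and its value is 66.5 nM. In this assay, no change beyond the scatter is therefore expected, with an estimated 1.0-fold higher number from compound 2 to compound 3 (0.02 log units; within the scatter). For compound 3, the expected value is 65 nM, within an estimated range of 22 nM to 190 nM.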

Compound 3, half-maximal inhibitory concentration: 413 nM
Compound 3: middle estimate off by 6.4-fold (0.80 log units), on the low side; measured number outside the range, above it.
By their numbers in this assay, from the lowest: compounds 2 and 1 (each within the scatter of the next); then compound 3.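

In this assay, (tert-butyl)amino in place of dipentylamino on the saturated chain carbon gives a 6.6-fold higher number from compound 2 to compound 3 (0.82 log units; beyond the scatter) and so shows that, with ethyl on the aromatic carbon, the two amino groups are not interchangeable. With (tert-butyl)amino kept, ethyl in place of cyclopropyl gives a 6.2-fold higher number from compound 1 to compound 3 (0.79 log units; beyond the scatter) and so shows that this aromatic carbon matters too. Compound 1 and compound 2 differ in both places and could show neither change alone. Nothing given here explains either step. Going by these compounds, how a diethylamino group or a piperidine would fall on either core stays open.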